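The source may hold more compounds than are shown below. What is called first, only, known or untested is meant among the compounds shown, and "the series" means these compounds.

Compound 1 `COc1cc(-c2cc(/C=C/C(=O)c3ccc(N)cc3)[nH]n2)cc(OC)c1OC` is the lowest of the two numbers recorded here. In a functional assay on HOP-62 cells (Homo sapiens) for cytotoxicity, read by sulforhodamine B assay, with a stated time of 48 h, tested at 10 uM (on this read-out higher numbers stand for a weaker effect at the one concentration tested and lower numbers for a stronger effect), compound 1 gives -59%, while compound 2 `COc1ccc(-c2cc(/C=C/C(=O)c3ccc(OC)c(OC)c3)[nH]n2)cc1` gives -25%, a gap beyond the usual scatter. Compound 3 `COc1cc(-c2cc(/C=C/C(=O)c3ccc(Cl)c(Cl)c3)[nH]n2)cc(OC)c1OC` is obtained from compound 1 by a single change: 3,4-dichlorophenyl in place of 4-aminophenyl on a carbonyl carbon. Within the data shown here, no pair of measured compounds shares this change, so its effect is unknown. Taking compound 1 as the reference point, the estimated outcome is compound 3 landing at -30%, within -75% to 15%. This corresponds to an expected step of a number 29 percentage points higher from compound 1 to compound 3 (beyond the scatter), a weakening beyond the scatter but with wide uncertainty.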

Compound 3, a percentage reported as activity, at one concentration (the size of the read-out at that concentration, not a potency): -9%
Beside the measured number, compound 3's estimate is 21 percentage points below it; measured number inside the range.
By their numbers in this assay, from the lowest: compound 1; then compound 2; then compound 3.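

Among these compounds, with the core of compound 1 held fixed, the group on this carbonyl carbon proves to matter greatly: in this assay, replacing 4-aminophenyl with 3,4-dichlorophenyl gives a large weakening, a number 50 percentage points higher from compound 1 to compound 3 (beyond the scatter), the first step here in which only one place changes. No measurement shown accounts for this step. The compounds shown leave open which part of the change carries the step, the loss of the amine or the arrival of the two chlorines. An unsubstituted phenyl on the same carbonyl carbon would separate the two.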